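The compounds below may be only part of what the source reports. "The series", "measured", "known", "first", "only" and "open" are said of these compounds alone.

Two amides sharing one core have so far been read in a functional assay on K562 cells (Homo sapiens) for antiproliferative activity, read by MTT assay, with a stated time of 24 h; a higher number here means a weaker inhibitor, a lower number a stronger inhibitor. Compound 1, `COC(=O)c1scc(-c2ccc(NC(=O)c3ccc4ccccc4c3)cc2)c1OC`, gives 10300 nM, and compound 2, `COC(=O)c1scc(-c2ccc(NC(=O)c3ccc(F)c(Cl)n3)cc2)c1OC`, gives 8250 nM. Compound 2 therefore stands level with compound 1 on these numbers, and neither can be ranked above the other.

The next structure is compound 3, `COC(=O)c1scc(-c2ccc(NC(=O)c3cccc(I)c3)cc2)c1OC`. It keeps the core of compound 2 and exchanges one group: 3-iodophenyl in place of 6-chloro-5-fluoropyridin-2-yl on a carbonyl carbon. Here 3-iodophenyl comes in place of 6-chloro-5-fluoropyridin-2-yl on a carbonyl carbon whose other neighbour is an amide-type nitrogen.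

For the measured compounds named here, only one measured step bears on this change, as it falls at the same carbonyl carbon: a 1.2-fold lower number from compound 1 to compound 2 (0.10 log units; within the scatter). That exchange of naphthalen-2-yl for 6-chloro-5-fluoropyridin-2-yl left the values within the scatter of each other. Going by the values given here, one step is thin evidence, and no measured compound carries 3-iodophenyl. Even so, no shift beyond the scatter is expected in this assay, and no direction can be favoured. The expected change is a 1.0-fold lower number from compound 2 to compound 3 (0.01 log units; within the scatter). For compound 3 the estimated value is 8000 nM, with an expected range from 3000 nM to 20000 nM.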

Compound 3, half-maximal inhibitory concentration: 14700 nM
Compound 3: middle estimate off by 1.8-fold (0.26 log units), on the low side, within the range that was stated.
By their numbers in this assay, from the lowest: compounds 2, 1 and 3 (each within the scatter of the next).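

At the carbonyl carbon, a third group can now be read in this assay: placing 3-iodophenyl on it in exchange for 6-chloro-5-fluoropyridin-2-yl gives a 1.8-fold higher number from compound 2 to compound 3 (0.25 log units; within the scatter) and in exchange for naphthalen-2-yl gives a 1.4-fold higher number from compound 1 to compound 3 (0.15 log units; within the scatter) as the second step. All three pairs at this position therefore lie within the scatter, including the pair in which a ring with a hetero atom and a hydrogen-bond acceptor gives way to a ring of carbon only, so on these compounds the choice among the three groups does not separate the values. No outside evidence is available to bear on this result.

The compounds shown leave open whether any group at this carbonyl carbon can move the number beyond the scatter, since all three groups are aromatic; a saturated alkyl chain, a carboxylic acid or an amine in that place could test this. They also leave open whether the values depend on the shared core rather than on this group, as the core is the same in all three compounds.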